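The compounds below may be only part of what the source reports. "The series", "measured", "known", "first", "only" and "open" are said of these compounds alone.

Within the data shown here, compound 2 `O=C(CN1CCCC1)Nc1ccc(-c2nc3ccccc3[nH]2)cc1` is the one compound here with a numbered result: in an ADME assay on MDBK cells (Bos taurus) for cytotoxicity, read by MTT assay, with a stated time of 96 h (a lower number here means that less compound is tolerated, a higher number that more compound is tolerated), compound 2 gives 70000 nM. The other compound, compound 1 `O=C(O)CCC(=O)Nc1ccc(-c2nc3cc(C(F)(F)F)ccc3[nH]2)cc1`, also carries a trifluoromethyl group. In this assay compound 1 gives only a limit of the assay, > 100000 nM, and no number. The unmeasured compound 3 `O=C(CN1CCCC1)Nc1ccc(-c2nc3cc(C(F)(F)F)ccc3[nH]2)cc1` differs from compound 2 in one place: trifluoromethyl in place of hydrogen on an aromatic carbon. Among the measured compounds shown here, no measured pair shows this change directly. The step of a 1.4-fold lower number from compound 2 to compound 3 (0.15 log units; within the scatter) is expected to be small, perhaps a slight drop, not clearly beyond the usual scatter. Compound 3 is therefore estimated at 50000 nM in this assay, within a range from 20000 nM to 120000 nM.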

Compound 3, half-maximal cytotoxic concentration: 15000 nM
Beside the measured number, compound 3's estimate is 3.3-fold (0.52 log units) above it; measured number outside the range, below it.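

On this aromatic carbon, trifluoromethyl in place of hydrogen is a real change: in this assay there is a 4.7-fold lower number from compound 2 to compound 3 (0.67 log units; beyond the scatter), so less compound is tolerated once the group is present. Replacing carboxymethyl with pyrrolidin-1-yl on the saturated chain carbon bound to the carbonyl carbon also matters, with an at least 6.6-fold lower number from compound 1 to compound 3 (0.82 log units; beyond the scatter). That step is open-ended, since compound 1 gives a limit of the assay and not a number: the limit of > 100000 nM in this assay, at which 1 of the 3 values shown sits.

From the compounds shown here alone, whether a single chlorine atom or a methyl group on this carbon would give a similar step remains open. So does the effect of a longer chain or another amine in place of pyrrolidin-1-yl.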